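Chloro for Fluoro on Compound 3: Expecting Little Change

This account rests on a few compounds, and the source may have more. Where it says the series, first, only, none or still open, it means among the compounds named here.

Three measured compounds share one core. In a functional assay on A549 cells (Homo sapiens) for cytotoxicity, read by CCK-8 assay, with a stated time of 24 h (a lower number here means a stronger inhibitor, a higher number a weaker inhibitor), compound 1 `C/C(=C\c1cc(-c2ccc(F)cc2)co1)C(N)=O` gives 14900 nM. Compound 2 `C/C(=C\c1cc(C2=CCCC2)co1)C(N)=O` gives 16600 nM in this assay, a value within the usual scatter of that of compound 1. Compound 3 `C/C(=C\c1cc(-c2ccc(F)cc2)cs1)C(N)=O` is reported in this assay only as a limit, > 50000 nM, a limit of the measurement rather than a number, as noted in the limit of > 50000 nM in this assay, at which 1 of the 3 values shown sits. Compound 3 thus stands at the edge of what this measurement can resolve. Compound 4 `C/C(=C\c1cc(-c2ccc(Cl)cc2)cs1)C(N)=O` differs from compound 3 by chloro in place of fluoro on an aromatic carbon. Among the measured compounds shown here, no measured pair shows the effect of this swap here. The expected step of a number no higher from compound 3 to compound 4 (the limit leaves the size open) should stay within the usual scatter, with no clear direction. Compound 4 is estimated at 50000 nM, between 20000 nM and 150000 nM.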

Compound 4, half-maximal inhibitory concentration: > 50000 nM
Compound 4: only a limit was reported; the forecaster's own chance of this, stated with the estimate: 70%; the middle value sits exactly at the limit.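

In this assay compound 3 and compound 4 are both reported only as limits, so the swap of chloro for fluoro gives no readable step: the limit of > 50000 nM in this assay, at which 2 of the 4 values shown sit.

From the compounds shown here alone, whether chloro and fluoro differ at all in their effect on this thiophene-free reading of the shared core stays open.

Correction, final wording: whether chloro and fluoro differ at all in their effect on the shared core stays open.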